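This account rests on a few compounds, and the source may have more. Where it says the series, first, only, none or still open, it means among the compounds named here.

Measured in a functional assay on MCF7 cells (Homo sapiens) for antiproliferative activity, read by MTT assay, with a stated time of 48 h; a higher number here means a weaker inhibitor, a lower number a stronger inhibitor:
Compound 1 `CC(=O)N1N=C(c2ccc3ccccc3c2)OC1c1ccccc1`: 2.43 ug/mL
Compound 2 `CC(=O)N1N=C(c2ccc3ccccc3c2)OC1c1ccc(Br)cc1`: 5.07 ug/mL
Compound 3 `CC(=O)N1N=C(c2ccc3ccccc3c2)OC1c1ccccc1[N+](=O)[O-]`: 18.2 ug/mL

Compound 2 holds the middle place among these three numbers, with compound 1 on its lower side and compound 3 on its higher side. Compound 4 `CC(=O)N1N=C(c2ccc3ccccc3c2)OC1c1ccccc1O` has not yet been measured. It differs from compound 2 as follows: 2-hydroxyphenyl in place of 4-bromophenyl on a saturated ring carbon. In words, this is 2-hydroxyphenyl in place of 4-bromophenyl on a saturated ring carbon.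

Within the data shown here, no measured compound carries this group, so the evidence is indirect. Both measured replacements of hydrogen gave a higher number: bromo gave a 2.1-fold higher number from compound 1 to compound 2 (0.32 log units; beyond the scatter), and nitro gave a 7.5-fold higher number from compound 1 to compound 3 (0.87 log units; beyond the scatter). Compound 3 also shows how far a change at this place can reach, with a 3.6-fold higher number from compound 2 to compound 3 (0.56 log units; beyond the scatter). On that basis, only a small upward shift is expected, and it may not clear the usual scatter. The expected step is a 1.4-fold higher number from compound 2 to compound 4 (0.14 log units; within the scatter). In this assay, the estimated value for compound 4 is 7 ug/mL, within an expected range of 2.5 ug/mL to 20 ug/mL.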

Compound 4, half-maximal inhibitory concentration: 2.12 ug/mL
The estimate for compound 4 lay 3.3-fold (0.52 log units) above the measured number; measured number below the stated range.
By their numbers in this assay, from the lowest: compounds 4 and 1 (each within the scatter of the next); then compound 2; then compound 3.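

In this assay, both earlier replacements of hydrogen on an aromatic carbon gave a higher number, and hydroxy breaks that run: a 1.1-fold lower number from compound 1 to compound 4 (0.06 log units; within the scatter) is what it gives in place of hydrogen. The identity of the group therefore matters here, not just the presence of one, as hydroxy in place of nitro gives an 8.6-fold lower number from compound 3 to compound 4 (0.93 log units; beyond the scatter) and 2-hydroxyphenyl in place of 4-bromophenyl gives a 2.4-fold lower number from compound 2 to compound 4 (0.38 log units; beyond the scatter) on the saturated ring carbon. Nothing available here explains why these groups differ.

The bromo group belongs to a 4-bromophenyl, while the nitro and hydroxy groups belong to 2-substituted rings, so the effect of the group's location remains separate and unresolved. On these data alone, whether an amine or a methoxy group would also match the unsubstituted compound 1 remains open.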